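The source may hold more compounds than are shown below. What is called first, only, known or untested is meant among the compounds shown, and "the series" means these compounds.

In a functional assay on NCI-N87 cells (Homo sapiens) for inhibition, read by CellTiter-Glo, with a stated time of 72 h (a lower number here means a stronger inhibitor, a higher number a weaker inhibitor), compound 1 (`C=C(F)C(=O)Nc1cc2c(Nc3ccc(Oc4cc5nncn5cn4)c(C)c3)ncnc2cc1OCC`) gives 6.56 nM, while compound 2 (`Cc1cc(Nc2ncnc3cc(O)c(NC(=O)/C=C/[C@H]4CCCN4C)cc23)ccc1Oc1cc2nccn2cn1`) gives 41.7 nM, the higher of the two numbers and so the weaker inhibitor of this pair. Compound 3 (`Cc1cc(Nc2ncnc3cc(O)c(NC(=O)/C=C/[C@H]4CCCN4C)cc23)ccc1Oc1cnn2cnnc2c1`) differs from compound 2 in one place: a group of 9 heavy atoms (5 carbon, 4 nitrogen; one five-membered aromatic ring with 3 hetero atoms, one six-membered aromatic ring with 2 hetero atoms) in place of a group of 9 heavy atoms (6 carbon, 3 nitrogen; one five-membered aromatic ring with 2 hetero atoms, one six-membered aromatic ring with 2 hetero atoms), on an oxygen on an aromatic ring. Among the compounds with values here, no measured pair shows this kind of swap on its own, so no step beyond the usual scatter is expected in this assay, with at most a slight drift toward a lower number. The estimated change is a 1.4-fold lower number from compound 2 to compound 3 (0.14 log units; within the scatter). The expected value for compound 3 is 30 nM, within an estimated range of 10 nM to 90 nM.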

Compound 3, half-maximal inhibitory concentration: 28.3 nM
Compound 3: middle estimate off by 1.1-fold (0.03 log units), on the high side; the measured number falls inside the stated range.
By their numbers in this assay, from the lowest: compound 1; then compounds 3 and 2 (each within the scatter of the next).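

Within the data shown here, compound 2 and compound 3 form the first pair in this assay that differs in one place only, the two-ring group on an oxygen on an aromatic ring. Exchanging a carbon for a nitrogen in that group gives a 1.5-fold lower number from compound 2 to compound 3 (0.17 log units; within the scatter), so the two groups cannot be told apart in this assay. Nothing available explains this result. As far as these compounds go, it remains open how a single phenyl ring or a methyl group on that oxygen would read. From the compounds shown here alone, whether the same exchange behaves alike with another amide chain is also open.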